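A few compounds are considered here, and "the series" means these few. Any claim that something is new, unique, unknown or untested is made for them only; others in the source may bear on it.

Measured so far:
compound 2 `COc1ccc(-c2cnc(NC(=O)C3CCOCC3)n2C)cc1` — > 100000 nM
compound 1 `COc1ccc(-c2cnc(NC(=O)c3ccc([N+](=O)[O-])cc3)n2C)cc1` — > 100000 nM

In a toxicity assay on THP-1 cells (Homo sapiens) for inhibition (on this read-out lower numbers stand for higher toxicity in this test and higher numbers for lower toxicity in this test), compound 2 gives > 100000 nM, which is a limit of the assay and not a number. Compound 1 gives > 100000 nM, again a limit. Among the measured compounds shown here, compound 2 thus stands at the limit of > 100000 nM in this assay, at which 2 of the 2 values shown sit, and no measured step exists to place it more finely. Compound 3 `COc1ccc(C(=O)Nc2ncc(-c3ccc(OC)cc3)n2C)cc1` is not yet measured; it differs from compound 2 by 4-methoxyphenyl in place of oxan-4-yl on a carbonyl carbon. For the measured compounds named here, no step of this kind has been measured here. In this assay the expected change is none beyond the scatter, that is a number no higher from compound 2 to compound 3 (the limit leaves the size open). Compound 3 is therefore estimated at 100000 nM, with a range from 30000 nM to 300000 nM.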

Compound 3, half-maximal cytotoxic concentration: > 100000 nM
Compound 3: only a limit was reported; the forecaster's own chance of this, stated with the estimate: 70%; the middle value sits exactly at the limit.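

Compound 3 gives > 100000 nM in this assay, which is a limit and not a number. Its steps from compound 1 and compound 2 cannot be read, since all three compounds share one limit: the limit of > 100000 nM in this assay, at which 3 of the 3 values shown sit.

From the compounds shown here alone, how compound 1, compound 2 and compound 3 rank against one another in toxicity stays open.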